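The compounds below may be only part of what the source reports. "The series", "measured", "known", "first", "only" and "open" are said of these compounds alone.

Measured compounds in an ADME assay on BCBL1 cells (Homo sapiens) for cytotoxicity, with a stated time of 7 days; on this read-out lower numbers stand for higher toxicity in this test and higher numbers for lower toxicity in this test:
- compound 1, `CCCCSc1nc(N)nc2c1ncn2/C=C1/CC1(CO)CO`; in this assay compound 1 gives > 20000 nM, a limit of the assay rather than a number.
- compound 2, `CC(C)CSc1nc(N)nc2c1ncn2/C=C1/CC1(CO)CO`; in this assay compound 2 gives > 20000 nM, again only a limit.
- compound 3, `CC(C)CNc1nc(N)nc2c1ncn2/C=C1/CC1(CO)CO`; in this assay compound 3 gives > 20000 nM, likewise a limit.

Compound 3 therefore stands nowhere on a scale of numbers: its value is a limit, and the two other values shown are limits as well, all three sitting at the limit of > 20000 nM in this assay, at which 3 of the 3 values shown sit.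

The next compound, compound 4, is `CCCCCCSc1nc(N)nc2c1ncn2/C=C1/CC1(CO)CO`. Against compound 3 the change is hexylsulfanyl in place of isobutylamino on an aromatic carbon.

Going by the values given here, two measured steps touch the same aromatic carbon: a step that the two limits leave unreadable from compound 1 to compound 3 and a step that the two limits leave unreadable from compound 2 to compound 3. A third step alters the chain on a saturated carbon bound to sulfur, a step that the two limits leave unreadable from compound 1 to compound 2. None of the three can be sized, so no direction can be read for a longer sulfur-bound chain. Nothing in this assay separates any member of the series from the others.

Among the compounds with values here, for compound 4 the expectation is accordingly a step that the limit leaves unreadable from compound 3 to compound 4, none beyond the scatter, because every value so far rests at the limit of > 20000 nM in this assay, at which 3 of the 3 values shown sit. Compound 4 is thus expected to give about 30000 nM, within 10000 nM to 100000 nM, most probably reported once more as a limit.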

Compound 4, half-maximal cytotoxic concentration: > 20000 nM
Compound 4: only a limit was reported (the forecaster's own chance of this, stated with the estimate: 80%); the middle value is on the limit's open side.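

No step to compound 4 from compound 1, compound 2 or compound 3 can be read in this assay, because all four results are limits: the limit of > 20000 nM in this assay, at which 4 of the 4 values shown sit.

The compounds shown leave open whether hexylsulfanyl, butylsulfanyl, isobutylsulfanyl or isobutylamino on the shared core makes any difference in this assay.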